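Moving the Ring Nitrogen on the Aryloxy Substituent

The source may hold more compounds than are shown below. What is called first, only, known or untested is meant among the compounds shown, and "the series" means these compounds.

The compounds share one core and differ only on an oxygen on an aromatic ring. Compound 1 `CC(C)CCn1ccc(-c2ccc(OCC3CC3)cc2)c(C#N)c1=O` carries cyclopropylmethyl there, and in a functional assay on CHO cells for positive allosteric modulation of metabotropic glutamate receptor 2 (Homo sapiens), read by scintillation counting and GTPgammaS binding, with a stated time of 30 min (on this read-out lower numbers stand for smaller maximal responses and higher numbers for larger maximal responses), compound 1 gives 192%. For the measured compounds named here, compound 2 `CC(C)CCn1ccc(-c2ccc(Oc3ccccn3)cc2)c(C#N)c1=O` carries pyridin-2-yl, and in this assay compound 2 gives 249%, the highest of the two numbers; the single measured step is a number 57 percentage points higher from compound 1 to compound 2 (beyond the scatter). Compound 3 `CC(C)CCn1ccc(-c2ccc(Oc3ccncc3)cc2)c(C#N)c1=O` has not been measured; it differs from compound 2 by pyridin-4-yl in place of pyridin-2-yl on an oxygen on an aromatic ring. Going by the values given here, no measured step exchanges one pyridinyl for another, so the step from cyclopropylmethyl to pyridin-2-yl offers only indirect guidance: it shows that a large change at this position can move the response strongly, whereas the two pyridinyl groups keep the same atoms. One therefore expects for compound 3 a step of a number 19 percentage points lower from compound 2 to compound 3 (beyond the scatter) in this assay, within the scatter. Compound 3 is estimated at 230%, ranging from 170% to 285%.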

Compound 3, largest response reached (Emax), in percent of the reference or control that the assay uses: 245%
Compound 3: the middle estimate sits 15 percentage points below what was measured; the measured number falls inside the stated range.
By their numbers in this assay, from the lowest: compound 1; then compounds 3 and 2 (each within the scatter of the next).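

Shifting the ring nitrogen from pyridin-2-yl to pyridin-4-yl does not separate the two groups in this assay, with a number 4 percentage points lower from compound 2 to compound 3 (within the scatter) and so no difference that can be read between them. Set against cyclopropylmethyl, the pyridin-4-yl group also stands clearly apart, with a number 53 percentage points higher from compound 1 to compound 3 (beyond the scatter) in the same read-out. Among the compounds shown, then, the large step on this oxygen on an aromatic ring is not confined to pyridin-2-yl, and the place of the ring nitrogen has no readable effect between these two groups.

The compounds shown leave open whether pyridin-3-yl, or a plain phenyl without any ring nitrogen, would stand with the two pyridinyl groups or nearer to cyclopropylmethyl. There is no evidence here that bears on why the two pyridinyl groups read alike.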